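This account rests on a few compounds, and the source may have more. Where it says the series, first, only, none or still open, it means among the compounds named here.

- compound 1 `C/C(=N\NC(=O)c1cccc(S(=O)(=O)N2CCOCC2)c1)c1cccc(N)c1` gives > 100000 nM (a limit)
- compound 2 `C/C(=N\NC(=O)c1cccc(S(=O)(=O)N2CCOCC2)c1)c1cc(O)ccc1O` gives > 100000 nM (a limit)
- compound 3 `COc1ccc(/C=N/NC(=O)c2cccc(S(=O)(=O)N3CCOCC3)c2)c(O)c1` gives 5140 nM (a number)

For the measured compounds named here, in a functional assay on MCF7 cells (Homo sapiens) for antiproliferative activity, read by MTT assay, with a stated time of 72 h (on this read-out lower numbers stand for stronger inhibition and higher numbers for weaker inhibition), compound 3 gives 5140 nM and this is the only true number here. Compound 1 gives > 100000 nM as a limit, not a number. Compound 2 gives > 100000 nM as a limit too. Both sit at the limit of > 100000 nM in this assay, at which 2 of the 3 values shown sit, and neither can be placed more exactly. Going by the values given here, the only measured step is a step that the two limits leave unreadable from compound 1 to compound 2 and it offers no size to carry over.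

Compound 4 `O=C(N/N=C/c1cc(Br)cc(Br)c1O)c1cccc(S(=O)(=O)N2CCOCC2)c1` carries 3,5-dibromo-2-hydroxyphenyl in place of 2-hydroxy-4-methoxyphenyl on a carbon with a double bond to nitrogen. Among the compounds with values here, no measured step covers this change, so the anchor stays compound 3 at 5140 nM and no shift beyond the scatter is expected in either direction. The estimated move is a 1.3-fold lower number from compound 3 to compound 4 (0.11 log units; within the scatter) in this assay and its direction is uncertain. For compound 4 the estimate is 4000 nM with an expected range between 700 nM and 30000 nM on this read-out.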

Compound 4, half-maximal inhibitory concentration: 16000 nM
For compound 4 the middle estimate is 4.0-fold (0.60 log units) below the measured one; the range from low to high includes it.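

In this assay, the 2-hydroxy-4-methoxyphenyl group on a carbon with a double bond to nitrogen can be replaced by 3,5-dibromo-2-hydroxyphenyl with a measurable value kept, giving a 3.1-fold higher number from compound 3 to compound 4 (0.49 log units; beyond the scatter). For the compounds shown here, this is the first step here with a readable size, since the earlier step between two limits cannot be read. Nothing measured here bears on what lies behind this step.

Going by these compounds, the change removes the methoxy group and adds two bromines together, so their separate shares stay open. On these data alone, how a carboxylic acid or a chlorine on this ring would fare also remains unknown.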